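The source may hold more compounds than are shown below. What is called first, only, known or untested is meant among the compounds shown, and "the series" means these compounds.

Compound 1, drawn as `c1ccc(C2CCN(Cc3nc4ccccc4[nH]3)CC2)nc1`, is the weakest-looking member of a small set tested in a functional assay on HEK293 cells for agonist activity at D(4) dopamine receptor (Homo sapiens), read by FLIPR (on this read-out higher numbers stand for larger maximal responses and lower numbers for smaller maximal responses), where compound 1 reaches 62%. Compound 2, with the structure `Cc1cccc(C(=O)NCN2CCC(c3ccccn3)CC2)c1`, belongs to a different core; how the two cores differ is not broken down here. In this assay compound 2 gives 67%, a number within the scatter of that of compound 1, so no order between them can be claimed. Compound 3, drawn as `Cc1cccc(C(=O)NCN2CCC(c3cccc[n+]3[O-])CC2)c1`, carries a group of 7 heavy atoms (5 carbon, 1 nitrogen, 1 oxygen; one six-membered aromatic ring with 1 hetero atom) in place of a group of 6 heavy atoms (5 carbon, 1 nitrogen; one six-membered aromatic ring with 1 hetero atom), on a saturated ring carbon. The step from the second to the third compound is a number 10 percentage points higher from compound 2 to compound 3 (within the scatter), and compound 3 gives 77% in this assay, a number beyond the scatter of compound 1.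

Compound 4, with the structure `[O-][n+]1ccccc1C1CCN(Cc2nc3ccccc3[nH]2)CC1`, has not yet been measured. It carries a group of 7 heavy atoms (5 carbon, 1 nitrogen, 1 oxygen; one six-membered aromatic ring with 1 hetero atom) in place of a group of 6 heavy atoms (5 carbon, 1 nitrogen; one six-membered aromatic ring with 1 hetero atom), on a saturated ring carbon. The place is described word for word as for the change from compound 2 to compound 3, so this is the same change, now applied to the core of compound 1. Within the data shown here, only one measured pair shows this change, so the expectation rests on a single step. For compound 4 the expected step is a number 10 percentage points higher from compound 1 to compound 4 (within the scatter), because a number 10 percentage points higher from compound 2 to compound 3 (within the scatter) was seen for the same change on the other core. Compound 4 is therefore estimated to reach 72% in this assay, with a likely span from 60% to 84%.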

Compound 4, largest response reached (reported as efficacy), in percent of the reference or control that the assay uses: 54%
Beside the measured number, compound 4's estimate is 18 percentage points above it; the whole stated range lies above it.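

In this assay, replacing pyridin-2-yl with the oxygen-bearing ring gives a number 8 percentage points lower from compound 1 to compound 4 (within the scatter), and setting this beside the earlier step shows that the change does not have one transferable effect across these two cores: the same change on two cores in this assay, a number 10 percentage points higher (within the scatter) from compound 2 to compound 3 and a number 8 percentage points lower (within the scatter) from compound 1 to compound 4, 18 percentage points apart, beyond the scatter of two such steps Each step on its own stays within the scatter, so neither core alone establishes that the change raises or lowers the maximal response; only the gap between the two steps can be read, and it warns against adding a step seen on one core to another core. The comparison does not show why the cores differ, which part of either core matters, or how the change would behave on any other core, since each core contributes just one pair.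

The compounds shown leave open whether a third core would follow the step seen from compound 2 to compound 3, the step seen from compound 1 to compound 4, or neither. They also leave open whether a different group at the same saturated ring carbon, such as a phenyl ring or a carboxylic acid, would give steps that agree across the two cores.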